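A few compounds are considered here, and "the series" means these few. Any claim that something is new, unique, unknown or untested is made for them only; others in the source may bear on it.

Working notes on the series.

Compound 1 `Oc1cccc(-c2cc(-c3ccc(F)cc3)cc(-c3cccc(O)c3)n2)c1` is the reference point. In a functional assay on DU-145 cells (Homo sapiens) for inhibition (a lower number here means a stronger inhibitor, a higher number a weaker inhibitor), compound 1 gives 7120 nM. Compound 2 `Oc1ccc(-c2cc(-c3ccc(F)cc3)cc(-c3cccc(O)c3)n2)cc1` differs from it by a single change, (4-hydroxyphenyl in place of 3-hydroxyphenyl on an aromatic carbon). In this assay compound 2 gives 15200 nM. The step of a 2.1-fold higher number from compound 1 to compound 2 (0.33 log units; beyond the scatter) is modest but beyond the scatter, so the 4-hydroxyphenyl group costs some potency on this core.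

Compound 3 `Oc1cccc(-c2cc(-c3cccc(OC(F)(F)F)c3)cc(-c3ccccc3O)n2)c1` has a different core; how its core differs from that of compound 1 is not broken down here. In this assay compound 3 reaches only the limit of the assay, > 50000 nM, and no number is known for it. This is the limit noted as the limit of > 50000 nM in this assay, at which 1 of the 3 values shown sits.

Compound 4 `Oc1ccc(-c2cc(-c3cccc(OC(F)(F)F)c3)cc(-c3ccccc3O)n2)cc1` has not yet been measured. It differs from compound 3 by 4-hydroxyphenyl in place of 3-hydroxyphenyl on an aromatic carbon. The surroundings of the change are not identical to those in compound 1: there the altered position is meta to a 3-hydroxyphenyl group and meta to a 4-fluorophenyl group, whereas in compound 3 it is meta to a 2-hydroxyphenyl group and meta to a large group. It is therefore the same kind of change, not the same change.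

The expected step that the limit leaves unreadable from compound 3 to compound 4 is set beside the measured 2.1-fold higher number from compound 1 to compound 2 (0.33 log units; beyond the scatter), because a 2.1-fold higher number from compound 1 to compound 2 (0.33 log units; beyond the scatter) moved the number upward on the other core. Compound 3 already sits at the limit, so an upward step would most likely leave compound 4 at the limit as well. Compound 4 is expected to give about 90000 nM, estimated to lie between 40000 nM and 250000 nM, most probably reported only as a limit.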

Compound 4, half-maximal inhibitory concentration: > 50000 nM
Compound 4: no number, only a limit; the forecaster's own chance of this, stated with the estimate: 85%; the middle value does not contradict the limit.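

In this assay compound 4 gives only a limit, > 50000 nM, and not a number. Compound 3 also stands at a limit, so no step can be read between compound 3 and compound 4: the limit of > 50000 nM in this assay, at which 2 of the 4 values shown sit.

The compounds shown leave open whether 4-hydroxyphenyl in place of 3-hydroxyphenyl changes potency on the core of compound 3 as it does on the core of compound 1.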